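The source may report more compounds than this note shows. Statements on the series, on what has been measured and on what is new or still open speak of the compounds shown alone.

Measured compounds:
compound 1 `N#C/C(=C\c1c(-c2ccccc2)[nH]c2ccccc12)C(=O)c1ccccc1` — 15200 nM
compound 2 `CCOC(=O)C(=Cc1c(-c2ccccc2)[nH]c2ccccc12)C(=O)OCC` — 13600 nM
compound 3 `O=C(/C(=C\c1c(-c2ccccc2)[nH]c2ccccc12)S(=O)(=O)c1ccccc1)c1ccccc1` — 7600 nM

In a functional assay on SK-OV-3 cells (Homo sapiens) for inhibition, read by sulforhodamine B assay, with a stated time of 48 h (on this read-out lower numbers stand for stronger inhibition of growth and higher numbers for weaker inhibition of growth), compound 3 gives 7600 nM. Its gaps to compound 2 and to compound 1 both lie within the usual scatter, so the three compounds cannot be told apart on these numbers and none stands out. Compound 4 `CC(=O)/C(=C\c1c(-c2ccccc2)[nH]c2ccccc12)S(=O)(=O)c1ccccc1` is not yet measured. It differs from compound 3 in one place only: methyl in place of phenyl on a carbonyl carbon. Among the measured compounds shown here, no measured pair shows this change, so there is nothing in the data to point in either direction. The change is expected to produce no step beyond the scatter, with compound 4 estimated at 10000 nM (range 3500 nM to 30000 nM), which means an expected step of a 1.3-fold higher number from compound 3 to compound 4 (0.12 log units; within the scatter).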

Compound 4, concentration for 50% growth inhibition: 2900 nM
Estimate against measurement, compound 4: 3.4-fold (0.54 log units) above; the measured number lies below the stated range.
By their numbers in this assay, from the lowest: compound 4; then compounds 3, 2 and 1 (each within the scatter of the next).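

Among the compounds shown here, on the carbonyl carbon, the phenyl of compound 3 is not required for growth inhibition in this assay: the change from benzoyl to acetyl gives a 2.6-fold lower number from compound 3 to compound 4 (0.42 log units; beyond the scatter) and is the first difference in this set that clearly exceeds the usual scatter. This conclusion rests on a single pair, and nothing given here explains the step.

The compounds shown leave open whether an ethyl group, a longer chain or an amine on that carbonyl carbon would lower the number further. They also leave open whether the same change would produce a similar step in compound 1.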